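Fluoro for nitro on the hydroxymethyl aryl ring

The compounds below may be only part of what the source reports. "The series", "measured", "known", "first", "only" and "open" are said of these compounds alone.

For the measured compounds named here, compound 2 `Cc1oc2c([C@H]3CCN(C)C[C@H]3O)c(O)cc(O)c2c(=O)c1C(O)c1ccc([N+](=O)[O-])cc1` stands lowest of the two numbers measured so far: in a functional assay on HL-60 cells (Homo sapiens) for inhibition, read by MTT assay, with a stated time of 48 h, tested at 10 uM (a higher number here means more inhibition of growth at the concentration tested, a lower number less inhibition of growth), compound 2 gives 0%. Compound 1 `Cc1cc(=O)c2c(O)cc(OC/C=C/c3ccccc3)c([C@H]3CCN(C)C[C@H]3O)c2o1`, built on the shared core with a different substitution, gives 21% in this assay, a gap from compound 2 that lies beyond the scatter. Compound 3 `Cc1oc2c([C@H]3CCN(C)C[C@H]3O)c(O)cc(O)c2c(=O)c1C(O)c1ccc(F)cc1` differs from compound 2 in one place: fluoro in place of nitro on an aromatic carbon. Going by the values given here, no measured pair covers this change, so the step is only expected: a small rise, not beyond the scatter, a number 8 percentage points higher from compound 2 to compound 3 (within the scatter). Compound 3 is therefore estimated at 8% in this assay, within 0% to 25%.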

Compound 3, percent growth inhibition at one concentration: 30%
Estimate against measurement, compound 3: 22 percentage points below, outside the stated range (above it).
By their numbers in this assay, from the lowest: compound 2; then compounds 1 and 3 (each within the scatter of the next).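

The aromatic carbon para to a large group is not silent in this series: with 4-fluorophenyl in place of 4-nitrophenyl, this assay records a number 30 percentage points higher from compound 2 to compound 3 (beyond the scatter). For the compounds shown here, this is the first readable response to a single group change on this aryl ring, which compound 1 could not give, since it differs from compound 2 in more than one place. Nothing in hand accounts for this step.

On these data alone, it remains open whether other groups on this carbon, such as an amine, a carboxylic acid or methoxy, would follow the same course. A single pair also cannot separate a gain from fluoro from a loss imposed by nitro.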